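Trimming a tert-butyl to an ethyl on the ring

The source may hold more compounds than are shown below. What is called first, only, known or untested is meant among the compounds shown, and "the series" means these compounds.

Of the compounds shown here, two built on the same core have so far been tested in a functional assay on HCT-15 cells (Homo sapiens) for cytotoxicity, read by sulforhodamine B assay, tested at 10 uM; on this read-out lower numbers stand for less inhibition and higher numbers for more inhibition at the one concentration tested (going by the name of the read-out). Compound 1 `CC(=O)OC[C@H]1O[C@@H](n2cc(-c3cn(Cc4ccc(C(C)C)cc4)nn3)c(=O)[nH]c2=O)C[C@@H]1OC(C)=O` gives 96.5%. Compound 2 `CC(=O)OC[C@H]1O[C@@H](n2cc(-c3cc(-c4ccc(C(C)(C)C)cc4)no3)c(=O)[nH]c2=O)C[C@@H]1OC(C)=O` gives 53.8%, the lower of the two numbers; the nearest value, that of compound 1, stands well above it, beyond the usual scatter. These two compounds differ in more than one place. Their values can only be set side by side, and no single change can be read from them.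

Compound 3 `CCc1ccc(-c2cc(-c3cn([C@H]4C[C@H](OC(C)=O)[C@@H](COC(C)=O)O4)c(=O)[nH]c3=O)on2)cc1` has not yet been measured in this assay. It differs from compound 2 in one place: ethyl in place of tert-butyl on an aromatic carbon. No measured pair among these compounds shows a step of this kind, so the numbers give no direction for it. The change leaves the ring untouched and only shortens the chain on it, so the step of a number 3.8 percentage points lower from compound 2 to compound 3 (within the scatter) is expected to be small, possibly none beyond the scatter. Compound 3 is therefore expected to give about 50% in this assay, within a range from 25% to 75%.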

Compound 3, a percentage reported as inhibition, at one concentration (the size of the read-out at that concentration, not a potency): 92.2%
Compound 3: middle estimate off by 42.2 percentage points, on the low side, and the stated range ends below it.
By their numbers in this assay, from the lowest: compound 2; then compounds 3 and 1 (each within the scatter of the next).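

In this assay, going from 4-(tert-butyl)phenyl to 4-ethylphenyl gives a number 38.4 percentage points higher from compound 2 to compound 3 (beyond the scatter) and so shows that this position, para to a large group, is sensitive: a change confined to the chain on the ring is enough to move the read-out by a large step. Tert-butyl and ethyl both count no hydrogen-bond donors, no hydrogen-bond acceptors and no net charge, so this step appears without any change in those counts. No measurement at hand explains why the ethyl compound gives the higher number.

The compounds shown place only tert-butyl and ethyl at this position, so they cannot say whether the read-out follows chain size steadily or how a methyl, a longer chain such as butyl, an amine or a carboxylic acid would behave there. On these data alone, it also remains open whether the same exchange of tert-butyl for ethyl would give a step of similar size on the core of compound 1.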